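This account rests on a few compounds, and the source may have more. Where it says the series, first, only, none or still open, it means among the compounds named here.

Compound 1 `CCC(=O)N1CCc2nc(C#Cc3ccccc3)sc2C1`, compound 2 `CC(C)S(=O)(=O)N1Cc2nc(C#Cc3ccccc3)sc2C1`, compound 3 `O=S(=O)(C1CCCCC1)N1Cc2nc(C#Cc3ccccc3)sc2C1`.

In an assay on HEK293 cells for negative allosteric modulation of metabotropic glutamate receptor 5 (Homo sapiens), read by FLIPR, with a stated time of 1 h (a lower number here means a stronger inhibitor, a higher number a weaker inhibitor), compound 1 gives 38 nM and compound 2 gives 140 nM. For compound 3 the assay reports only a limit, > 10000 nM. Compound 3 thus stands at the limit of the assay (the limit of > 10000 nM in this assay, at which 1 of the 3 values shown sits). Compound 4 `O=S(=O)(N1CCCCC1)N1Cc2nc(C#Cc3ccccc3)sc2C1` differs from compound 3 by piperidin-1-yl in place of cyclohexyl on a sulfonyl sulfur. Among the measured compounds shown here, one measured step bears on this position: an at least 71-fold higher number from compound 2 to compound 3 (1.85 log units; beyond the scatter). Since a six-membered ring on the sulfonyl sulfur gave that large loss in compound 3, and compound 4 keeps a six-membered ring at the same place, no step beyond the scatter is expected in this assay. Compound 4 is therefore expected to give about 8000 nM, with a range from 1500 nM to 30000 nM. The estimated step is an at least 1.2-fold lower number from compound 3 to compound 4 (0.09 log units; that floor lies within the scatter).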

Compound 4, half-maximal inhibitory concentration: > 10000 nM
Compound 4: only a limit was reported; the forecaster's own chance of this, stated with the estimate: 60%; middle value at least 1.2-fold (0.09 log units) away from the limit.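

Piperidin-1-yl in place of isopropyl on a sulfonyl sulfur gives an at least 71-fold higher number from compound 2 to compound 4 (1.85 log units; beyond the scatter) in this assay. The large loss seen with cyclohexyl is therefore not confined to a ring of carbon only, since a six-membered ring with a hetero atom brings it too. The step between compound 3 and compound 4 cannot be read, as both are reported only as limits, so any difference between these two rings stays hidden: the limit of > 10000 nM in this assay, at which 2 of the 4 values shown sit.

The compounds shown leave open where between isopropyl and these rings the loss sets in. Cyclopropyl or dimethylamino on the sulfonyl sulfur would test this.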